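The source may hold more compounds than are shown below. What is called first, only, known or untested is meant among the compounds shown, and "the series" means these compounds.

Measured compounds in this series:
- compound 1, `CC(C)=CC(=O)Nc1cc2c(N3CCCc4ccccc43)ncnc2cc1O[C@@H]1CCOC1`: 9020 nM
- compound 2, `CC/C=C/C(=O)Nc1cc2c(N3CCCc4ccccc43)ncnc2cc1O[C@@H]1CCOC1`: 14300 nM
- compound 3, `O=C(/C=C/CN1CCCC1)Nc1cc2c(N3CCCc4ccccc43)ncnc2cc1O[C@@H]1CCOC1`: 5780 nM

All three values come from a functional assay on PC-3 cells (Homo sapiens) for antiproliferative activity, read by MTT assay, with a stated time of 72 h; on this read-out lower numbers stand for stronger inhibition and higher numbers for weaker inhibition. Compound 3 gives the lowest of the three numbers in this assay; its nearest neighbour is compound 1, and the pair lies within the scatter, so no order between them can be claimed. Among the compounds with values here, the step of a 2.5-fold lower number from compound 2 to compound 3 (0.39 log units; beyond the scatter) is beyond the scatter and is the only one that separates compound 3 from another member of the set.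

Compound 4, `O=C(/C=C/CN1CCC(CO)CC1)Nc1cc2c(N3CCCc4ccccc43)ncnc2cc1O[C@@H]1CCOC1`, is not yet measured. It differs from compound 3 in one place: 4-(hydroxymethyl)piperidin-1-yl in place of pyrrolidin-1-yl on a saturated chain carbon bound to a double-bonded chain carbon.

The measured steps that bear on this change are a 1.6-fold lower number from compound 1 to compound 3 (0.19 log units; within the scatter) and a 2.5-fold lower number from compound 2 to compound 3 (0.39 log units; beyond the scatter), both of which concern the same saturated chain carbon; the step of a 1.6-fold higher number from compound 1 to compound 2 (0.20 log units; within the scatter) does not touch it. Nothing in the set tests a change from one saturated nitrogen ring to another at this carbon, nor the addition of a hydroxymethyl group. The amine is kept in compound 4, so the modest gain seen from compound 2 to compound 3 is expected to be retained rather than extended. For compound 4 the expected step is a 1.2-fold lower number from compound 3 to compound 4 (0.06 log units; within the scatter), within the scatter. Compound 4 is therefore estimated at 5000 nM in this assay, with a range from 2000 nM to 13000 nM.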

Compound 4, half-maximal inhibitory concentration: 5460 nM
Estimate against measurement, compound 4: 1.1-fold (0.04 log units) below; the range from low to high includes it.
By their numbers in this assay, from the lowest: compounds 4, 3, 1 and 2 (each within the scatter of the next, the first and the last beyond it).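

In this assay, the amine on this saturated chain carbon can change from a five-membered to a six-membered ring and gain a hydroxymethyl group with no readable effect: a 1.1-fold lower number from compound 3 to compound 4 (0.02 log units; within the scatter) lies within the scatter, although 4-(hydroxymethyl)piperidin-1-yl brings more heavy atoms and a hydrogen-bond donor that pyrrolidin-1-yl lacks. Against methyl on the same carbon, a second saturated nitrogen ring now gives a separation, with a 2.6-fold lower number from compound 2 to compound 4 (0.42 log units; beyond the scatter) beyond the scatter, while a 1.7-fold lower number from compound 1 to compound 4 (0.22 log units; within the scatter) stays within it, so the pattern holds only against the but-1-en-1-yl amide and not against the 2-methylprop-1-en-1-yl amide. No data here offer an explanation for these steps.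

As far as these compounds go, the ring change and the hydroxymethyl group arrive together in one step, so the separate contributions of each remain open, and plain piperidin-1-yl would be the informative group. Also open, from the compounds shown here alone, is whether morpholin-4-yl or dimethylamino on this carbon, or a carboxylic acid in place of the hydroxymethyl group, would give a number beyond the scatter from that of compound 3.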